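Sulfur side chain: from compound 3 to compound 4

The source may hold more compounds than are shown below. What is called first, only, known or untested is meant among the compounds shown, and "the series" means these compounds.

- compound 1 `Cc1cc(Nc2cc(-c3ccccc3)[nH]n2)n2nc(SCc3ccc([N+](=O)[O-])cc3)nc2n1` gives 7980 nM
- compound 2 `Cc1cc(Nc2cc(-c3ccccc3)[nH]n2)n2nc(SCC3CCCCC3)nc2n1` gives > 50000 nM which is a limit
- compound 3 `Cc1ccc(CSc2nc3nc(C)cc(Nc4cc(-c5ccccc5)[nH]n4)n3n2)cc1` gives 7310 nM
- compound 4 `Cc1cc(Nc2cc(-c3ccccc3)[nH]n2)n2nc(SCc3cccc4ccccc34)nc2n1` is not yet measured

In a functional assay on PC-9 cells (Homo sapiens) for inhibition, read by MTT assay, with a stated time of 72 h (a higher number here means a weaker inhibitor, a lower number a stronger inhibitor), compound 3 gives 7310 nM and sits level with compound 1 (a 1.1-fold lower number from compound 1 to compound 3 (0.04 log units; within the scatter)). Compound 4 carries naphthalen-1-yl in place of 4-methylphenyl on a saturated chain carbon bound to a sulfur. Methyl in place of nitro left the number within the scatter, as that step shows. Cyclohexyl in place of 4-nitrophenyl moved it beyond the scatter (an at least 6.2-fold higher number from compound 1 to compound 2 (0.79 log units; beyond the scatter)), and 4-methylphenyl in place of cyclohexyl moved it back (an at least 6.8-fold lower number from compound 2 to compound 3 (0.83 log units; beyond the scatter)). Compound 4 keeps an aromatic group there, so no step beyond the scatter is expected, in either direction. The expected step is a 1.1-fold lower number from compound 3 to compound 4 (0.05 log units; within the scatter) in this assay. For compound 4 the estimated value is 6500 nM (range 2500 nM to 17000 nM).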

Compound 4, half-maximal inhibitory concentration: 3950 nM
Compound 4: the middle estimate sits 1.6-fold (0.22 log units) above what was measured, within the range that was stated.
By their numbers in this assay, from the lowest: compounds 4, 3 and 1 (each within the scatter of the next, the first and the last beyond it). At a limit, above all of these: compound 2.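

In this assay, naphthalen-1-yl with its second six-membered aromatic ring is accepted on this saturated chain carbon bound to a sulfur, giving a 1.9-fold lower number from compound 3 to compound 4 (0.27 log units; within the scatter). Against the 4-nitrophenyl group the same replacement gives a 2.0-fold lower number from compound 1 to compound 4 (0.31 log units; beyond the scatter), the first step among these aromatic groups to pass the scatter, and a modest one. Compound 2 stands at a limit, so an at least 12-fold lower number from compound 2 to compound 4 (1.10 log units; beyond the scatter) is only a bound, and it again sets cyclohexyl apart from an aromatic group here.

Still open, from the compounds shown here alone, is how naphthalen-2-yl, a longer chain to the sulfur, or an amine on the aromatic ring would compare.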